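A few compounds are considered here, and "the series" means these few. Any claim that something is new, unique, unknown or untested is made for them only; others in the source may bear on it.

Compound 1 `CCCC(=O)Nc1ccc(S(=O)(=O)Oc2ccccc2C(C)C)cc1`: in a functional assay on MCF7 cells (Homo sapiens) for antiproliferative activity, read by sulforhodamine B assay, with a stated time of 48 h (a higher number here means a weaker inhibitor, a lower number a stronger inhibitor), compound 1 gives 6600 nM.
Compound 2 `CC(C)C(=O)Nc1ccc(S(=O)(=O)Oc2ccccc2C(C)C)cc1`: in this assay compound 2 gives 8600 nM.

Within the data shown here, on the two numbers measured so far, compound 2 shows the higher value, though only by a step within the scatter: a 1.3-fold higher number from compound 1 to compound 2 (0.11 log units; within the scatter). That step exchanged propyl on a carbonyl carbon for isopropyl. Compound 3 `CC(C)c1ccccc1OS(=O)(=O)c1ccc(NC(=O)C(C)(C)C)cc1` carries the same kind of change one bond further: methyl in place of hydrogen on a saturated chain carbon bound to a carbonyl carbon and two saturated chain carbons, so the isopropylcarbonyl becomes a (tert-butyl)carbonyl. Among the measured compounds shown here, the only measured step that bears on this is the one between compound 1 and compound 2, which added a single carbon at the same place and stayed within the scatter. A comparable outcome is expected here, with no shift beyond the scatter, perhaps leaning toward a higher number. Compound 3 is therefore estimated at 10000 nM in this assay, within 4000 nM to 25000 nM, an expected step of a 1.2-fold higher number from compound 2 to compound 3 (0.07 log units; within the scatter).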

Compound 3, half-maximal inhibitory concentration: 6500 nM
The estimate for compound 3 lay 1.5-fold (0.19 log units) above the measured number; the measured number falls inside the stated range.
By their numbers in this assay, from the lowest: compounds 3, 1 and 2 (each within the scatter of the next).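

Adding one more methyl, which turns isopropyl into tert-butyl, gives a 1.3-fold lower number from compound 2 to compound 3 (0.12 log units; within the scatter) in this assay and so leaves this carbonyl carbon as insensitive as the earlier change from propyl to isopropyl suggested. The direct comparison of the unbranched chain with the most branched group gives a 1.0-fold lower number from compound 1 to compound 3 (0.01 log units; within the scatter) and shows that even the full change from propyl to tert-butyl stays inside the scatter, so branching of this small group has no readable effect among these three compounds. No measurement here offers an explanation for these close numbers.

From the compounds shown here alone, whether a different kind of group on this carbonyl carbon, such as an amine or a carboxylic acid, would move the number beyond the scatter remains open. Going by these compounds, a longer chain, such as hexyl, remains equally open.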